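This account rests on a few compounds, and the source may have more. Where it says the series, first, only, none or still open, it means among the compounds named here.

Measured compounds:
compound 1, `Cn1c(N2CCCC2)c(C#N)c2c(N)ncnc21`: 1480 nM
compound 2, `C[C@@H]1CCCN1c1c(C#N)c2c(N)nccc2n1C`: 34 nM
compound 3, `Cc1cn(C)nc1Nc1cc2c(c(N)n1)c(C#N)c(N1CCC[C@H]1C)n2C`: 2110 nM

In an assay on isolated protein for inhibition of Leucine-rich repeat serine/threonine-protein kinase 2 (Homo sapiens), read by TR-FRET and LanthaScreen, with stated times of 50 min and 30 min, in the presence of a further agent that is not named here (on this read-out higher numbers stand for weaker inhibition and lower numbers for stronger inhibition), compound 1 gives the second highest of the three numbers. Compound 3 gives 2110 nM, which sits within the scatter of compound 1, so the two are not separated. For the measured compounds named here, compound 2 gives 34 nM, a much lower number than compound 1; no single-change step joins these two compounds, since they also differ in the shared core and in the methyl on the pyrrolidine ring.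

Going by the values given here, the one step with a single change is a 62-fold higher number from compound 2 to compound 3 (1.79 log units; beyond the scatter), the addition of (1,4-dimethyl-1H-pyrazol-3-yl)amino on an aromatic carbon. It does not touch the group altered here.

Compound 4, `Cn1c(-c2ccccc2)c(C#N)c2c(N)ncnc21`, is not yet measured. It differs from compound 1 as follows: phenyl in place of pyrrolidin-1-yl on an aromatic carbon

Among the compounds with values here, no measured step bears on this change, so there is no basis for a direction from the series itself. The expectation for compound 4 rests on compound 1 alone, which gives 1480 nM, and is therefore taken as a number in the same region, with a wide range: compound 4 is estimated at 2500 nM (range 500 nM to 12000 nM), which means an expected step of a 1.7-fold higher number from compound 1 to compound 4 (0.23 log units; within the scatter).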

Compound 4, half-maximal inhibitory concentration: 1260 nM
For compound 4 the middle estimate is 2.0-fold (0.30 log units) above the measured one; the range from low to high includes it.
By their numbers in this assay, from the lowest: compound 2; then compounds 4, 1 and 3 (each within the scatter of the next).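

In this assay the step is a 1.2-fold lower number from compound 1 to compound 4 (0.07 log units; within the scatter), so at this position, on an aromatic carbon of a five-membered aromatic ring with 1 nitrogen, next to the ring nitrogen and next to the ring atom that bears a cyano group, the read-out does not separate pyrrolidin-1-yl from phenyl. The two groups differ in ring size, in being non-aromatic or aromatic, and in the hydrogen-bond acceptor counted for pyrrolidin-1-yl but not for phenyl, so on this core neither the attached ring nitrogen nor that acceptor is needed to keep the number in this region. Nothing in the data available accounts for this outcome.

As far as these compounds go, whether phenyl would read the same on the core of compound 2, which gives 34 nM with a methyl-substituted pyrrolidine at this position, stays open. Also open, from the compounds shown here alone, is how far this tolerance extends to other groups at this position, such as an open-chain amine like dimethylamino, a morpholin-4-yl ring or a pyridyl ring.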